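Mirror-image step from compound 2 to compound 3

The source may hold more compounds than are shown below. What is called first, only, known or untested is meant among the compounds shown, and "the series" means these compounds.

Two compounds of the series have numbers in an ADME assay on the whole organism with Oryza sativa as the target, tested at 0.1 uM; a lower number here means a stronger effect, a higher number a weaker effect of the compound at the concentration tested. Compound 1 `CCc1cccc(NC(=O)N[C@@H](C)c2ccccc2)c1` gives 100% in this assay. Compound 2 `C[C@@H](NC(=O)Nc1cccc(Cl)c1)c1ccccc1` gives 97% in this assay. Compound 2 stands lowest of the two, and its nearest neighbour is compound 1, whose number lies within the usual scatter of it, so the pair reads as alike rather than ordered. Among the measured compounds shown here, no step between measured compounds that differ in a single place is available, so the series gives no guide to how a single change moves this read-out.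

Compound 3 `C[C@H](NC(=O)Nc1cccc(Cl)c1)c1ccccc1` is the next to go into this assay. Its relation to compound 2: the two compounds have the same atoms and bonds and differ only in configuration as drawn: 1 of 1 stereo elements differ; a stereocentre at a saturated chain carbon is drawn R in compound 2 and S in compound 3. For the measured compounds named here, with both measured compounds sitting close together and no single-point step to lean on, the step of no change at the digits printed from compound 2 to compound 3 (within the scatter) is expected to stay within the scatter, in no particular direction. Compound 3 is estimated at 97%, with a range from 85% to 105%.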

Compound 3, a percentage reported as activity, at one concentration (the size of the read-out at that concentration, not a potency): 103%
Estimate against measurement, compound 3: 6 percentage points below, and the stated range covers the measured number.
By their numbers in this assay, from the lowest: compounds 2, 1 and 3 (each within the scatter of the next).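

In this assay the series now has its first single-place readings, and the stereocentre at the saturated chain carbon gives a number 6 percentage points higher from compound 2 to compound 3 (within the scatter), so S in place of R does not separate the pair. On the aromatic carbon, chloro in place of ethyl gives a number 3 percentage points higher from compound 1 to compound 3 (within the scatter), which again does not separate the two compounds. At this single concentration, neither change moves the read-out beyond the scatter, and the mirror-image pair isolates configuration as the only structural variable: the fact that compounds 2 and 3 differ only in the configuration as drawn

With all three compounds inside the scatter of one another, the series does not yet show any change that moves this read-out. Still open, as far as these compounds go, is how an amine or a carboxylic acid on the aromatic carbon, or a longer chain at the stereocentre, would read in this assay.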